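A few compounds are considered here, and "the series" means these few. Any claim that something is new, unique, unknown or untested is made for them only; others in the source may bear on it.

Of the compounds shown here, three that share one core have been tested in a functional assay on CHO cells for antagonist activity at prostaglandin E2 receptor EP4 subtype (Homo sapiens), read by calcium flux, with a stated time of 15 min; on this read-out higher numbers stand for weaker inhibition and lower numbers for stronger inhibition. Compound 1 `C[C@H](NC(=O)c1cnnn1Cc1ccc(C(F)(F)F)cc1)c1ccc(C(=O)O)cc1` carries a hydrogen at the place of interest, and in this assay compound 1 gives > 10000 nM, which is a limit of the assay rather than a number. Compound 2 `CCc1nnn(Cc2ccc(C(F)(F)F)cc2)c1C(=O)N[C@@H](C)c1ccc(C(=O)O)cc1` carries an ethyl there, and in this assay compound 2 gives > 10000 nM, again a limit and not a number. For the measured compounds named here, compound 3 `C[C@H](NC(=O)c1c(C2CCCC2)nnn1Cc1ccc(C(F)(F)F)cc1)c1ccc(C(=O)O)cc1` carries a cyclopentyl, and in this assay compound 3 gives 65.1 nM, the only true number among the three. Going from the hydrogen to the cyclopentyl brought an at least 150-fold lower number from compound 1 to compound 3 (2.18 log units; beyond the scatter), and going from the ethyl to the cyclopentyl brought an at least 150-fold lower number from compound 2 to compound 3 (2.18 log units; beyond the scatter); between the hydrogen and the ethyl there is a step that the two limits leave unreadable from compound 1 to compound 2, because both values sit at the limit of > 10000 nM in this assay, at which 2 of the 3 values shown sit. Going by the values given here, compound 3 therefore stands alone as the one compound with a measured number, and it is the starting point for compound 4 `C[C@H](NC(=O)c1c(C2CCCCC2)nnn1Cc1ccc(C(F)(F)F)cc1)c1ccc(C(=O)O)cc1`. The change is cyclohexyl in place of cyclopentyl on an aromatic carbon. Both steps that lead into compound 3 were large, but each exchanged a small group for a ring; widening that ring by one carbon is a much gentler alteration. The expected step of a 1.1-fold lower number from compound 3 to compound 4 (0.04 log units; within the scatter) is therefore small, with no direction that would stand out from the scatter. Compound 4 is estimated at 60 nM, within a range from 20 nM to 200 nM.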

Compound 4, half-maximal inhibitory concentration: 161 nM
Estimate against measurement, compound 4: 2.7-fold (0.43 log units) below; the measured number falls inside the stated range.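

In this assay, for the compounds shown here, the earlier compounds showed only that a cyclopentyl on this aromatic carbon of the five-membered aromatic ring gives a measurable number where a hydrogen or an ethyl does not. Adding one carbon to that ring now gives a 2.5-fold higher number from compound 3 to compound 4 (0.39 log units; beyond the scatter), so this position responds to a change as small as five-membered versus six-membered, and the smaller ring holds the lower number of the two. The cyclohexyl still keeps a large part of what the cyclopentyl gained, with an at least 62-fold lower number from compound 2 to compound 4 (1.79 log units; beyond the scatter) and an at least 62-fold lower number from compound 1 to compound 4 (1.79 log units; beyond the scatter), but these two steps start from values that are limits of the assay and not numbers: the limit of > 10000 nM in this assay, at which 2 of the 4 values shown sit.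

With only two ring sizes carrying true numbers, the compounds shown cannot say whether the trend would continue to a cycloheptyl or reverse at a cyclobutyl. They also leave open whether a ring is needed at all, which an open branched chain such as isopropyl or tert-butyl would test, and how a flat phenyl ring or a ring carrying an amine nitrogen would read at this place.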